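Cyclopropyl to pyrrolidinyl on the shared core

The source may hold more compounds than are shown below. What is called first, only, known or untested is meant among the compounds shown, and "the series" means these compounds.

Compound 1 `CN1CCN(CCCS(=O)(=O)c2ccc3nc(NC(=O)NC(=O)c4cc(C5CC5)ccc4Cl)sc3c2)CC1` is the more lipophilic of the two compounds measured in a physicochemical assay for lipophilicity (on this read-out higher numbers stand for higher lipophilicity and lower numbers for lower lipophilicity), where compound 1 gives 2.9. Its nearest neighbour, compound 2 `COc1cc(Cl)c(C(=O)NC(=O)Nc2nc3ccc(S(=O)(=O)CCCN4CCN(C)CC4)cc3s2)cc1-n1cccn1`, gives 2.2 in this assay, a gap that lies beyond the usual scatter; no single-point change connects these two, so their two numbers are all that can be said of the pair.

Compound 3 `CN1CCN(CCCS(=O)(=O)c2ccc3nc(NC(=O)NC(=O)c4cc(N5CCCC5)ccc4Cl)sc3c2)CC1` has not yet been measured. It differs from compound 1 at one place only: pyrrolidin-1-yl in place of cyclopropyl on an aromatic carbon. The group that leaves and the group that enters are both small, saturated rings attached to the same aromatic carbon, and the one heavy-atom difference between them lies in the nitrogen that joins the ring to the core.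

Going by the values given here, with no measured step of this kind among the compounds at hand, the author expects the change to move this assay little if at all, and estimates a step of a number 0.10 log units higher from compound 1 to compound 3 (within the scatter) from compound 1 to compound 3. The author therefore estimates compound 3 at 3, within a range from 2.5 to 3.5.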

Compound 3, distribution coefficient: 3.1
Beside the measured number, compound 3's estimate is 0.10 log units below it, within the range that was stated.
By their numbers in this assay, from the lowest: compound 2; then compounds 1 and 3 (each within the scatter of the next).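

In this assay, replacing cyclopropyl with pyrrolidin-1-yl on the aromatic carbon gives a number 0.20 log units higher from compound 1 to compound 3 (within the scatter), the first single-place step available in this series, and it leaves compound 1 and compound 3 indistinguishable on this read-out. The position therefore accepts a swap from a three-membered ring of carbon only, with 0 hydrogen-bond acceptors, to a five-membered ring with 1 hetero atom and 1 hydrogen-bond acceptor, with no separation between the two numbers beyond the usual scatter of repeated measurements. No measurement in hand accounts for this outcome.

What the compounds shown leave open is whether this holds for other groups at the same position, such as a morpholine ring, a primary amine or a carboxylic acid, since this one step is the only change there that can be read. Also open, from the compounds shown here alone, is whether a piperidine ring or an open-chain dimethylamino group would stay as close to compound 1, and whether the same exchange would give a similar step on a differently substituted ring.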